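A few compounds are considered here, and "the series" means these few. Any claim that something is new, unique, unknown or untested is made for them only; others in the source may bear on it.

Measured so far in an ADME assay on HEK293 cells (Homo sapiens) for cytotoxicity, with a stated time of 72 h (on this read-out lower numbers stand for an effect already at smaller amounts and higher numbers for an effect only at larger amounts of compound), each value a limit of the assay and not a number:

- Compound 1 `C=C[C@@](C)(/C=C/c1ccc(OC)cc1)CCC=C(C)C` gives > 36600 nM as a limit
- Compound 2 `C=C[C@@](C)(/C=C/c1ccc(Nc2ccccc2)cc1)CCC=C(C)C` gives > 36600 nM as a limit
- Compound 3 `C=C[C@@](C)(/C=C/c1ccc(Nc2ccc(OC)c(F)c2)cc1)CCC=C(C)C` gives > 36600 nM as a limit

Compound 2 therefore stands at > 36600 nM as a limit only. The other two compounds offer no number to compare it with, and the limit of > 36600 nM in this assay, at which 3 of the 3 values shown sit, is the whole picture so far.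

Compound 4 `C=C[C@@](C)(/C=C/c1ccc(Nc2ccc(OC(F)(F)F)cc2)cc1)CCC=C(C)C` carries one change from compound 2 (trifluoromethoxy in place of hydrogen on an aromatic carbon): trifluoromethoxy in place of hydrogen on an aromatic carbon, para to a large group.

Going by the values given here, two measured steps bear on this change, and neither has a readable size (a step that the two limits leave unreadable from compound 1 to compound 2) (a step that the two limits leave unreadable from compound 2 to compound 3). The second is the closer of the two, since it also replaces the phenyl on the nitrogen. Neither gives a direction, so no step beyond the scatter is expected in this assay from this change.

The expected step is (a step that the limit leaves unreadable from compound 2 to compound 4) on this estimate. For compound 4 the estimated value is 40000 nM with an expected range of 15000 nM to 100000 nM overall, and a further limit is the likeliest report.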

Compound 4, half-maximal effective concentration: > 36600 nM
Compound 4: only a limit was reported; the forecaster's own chance of this, stated with the estimate: 80%; the middle value does not contradict the limit.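

In this assay, going by these compounds alone, compound 4 gives > 36600 nM, again a limit and not a number, so no step between compound 2 and compound 4 can be read. The compounds shown leave open at what concentration any of them would show an effect and whether these changes would shift it, as all share one limit: the limit of > 36600 nM in this assay, at which 4 of the 4 values shown sit.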